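The source may report more compounds than this note shows. Statements on the series, on what has been measured and on what is new or still open speak of the compounds shown alone.

Measured so far in an assay on isolated protein for inhibition of DNA topoisomerase 1 (Homo sapiens), with a stated time of 30 min, tested at 100 uM; on this read-out higher numbers stand for more inhibition at the one concentration tested (going by the name of the read-out) and lower numbers for less inhibition:
compound 1 `C[C@@H]1O[C@@H](OCC#Cc2c(-c3ccccc3)oc3ccccc23)C[C@H](N)[C@H]1O` gives 25.5%
compound 2 `C[C@@H]1O[C@@H](OCC#Cc2c(-c3ccccc3)sc3ccccc23)C[C@H](N)[C@@H]1O` gives 36.9%
compound 3 `C[C@@H]1O[C@@H](OCC#Cc2c(-c3ccccc3)[nH]c3ccccc23)CC[C@@H]1N` gives 4%

Compound 3 stands lowest of the three numbers; the nearest, compound 1, lies beyond the scatter above it, and compound 2 lies further still. Compound 4 `C[C@@H]1O[C@@H](OCC#Cc2c(-c3ccccc3)[nH]c3ccccc23)C[C@H](N)[C@@H]1O` is not yet measured. It differs from compound 3 in one place: a group of 9 heavy atoms (6 carbon, 1 nitrogen, 2 oxygen; one six-membered non-aromatic ring with 1 hetero atom) in place of a group of 8 heavy atoms (6 carbon, 1 nitrogen, 1 oxygen; one six-membered non-aromatic ring with 1 hetero atom), on an oxygen on a saturated carbon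

For the measured compounds named here, no measured pair shows this step on its own, so its size is open. Going by the values given here, the entering group is the one carried by compound 1 and compound 2, both of which give higher numbers than compound 3 in this assay, so a rise beyond the scatter is expected, of the size a number 16 percentage points higher from compound 3 to compound 4 (beyond the scatter). For compound 4 the estimate is 20%, expected to fall between 4% and 38%.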

Compound 4, a percentage reported as inhibition, at one concentration (the size of the read-out at that concentration, not a potency): 8.8%
Compound 4: middle estimate off by 11.2 percentage points, on the high side, within the range that was stated.
By their numbers in this assay, from the lowest: compounds 3 and 4 (each within the scatter of the next); then compound 1; then compound 2.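

Replacing 5-amino-6-methyloxan-2-yl with the group of 9 heavy atoms, on an oxygen on a saturated carbon, gives a number 4.8 percentage points higher from compound 3 to compound 4 (within the scatter) in this assay. At this position, on this core, the change alone therefore does not separate the two compounds, and the higher numbers of compound 1 and compound 2 cannot be credited to the entering group alone. No supporting data explain this result.

Going by these compounds, whether an acetamide or a longer chain in place of the amine would shift the number remains open. So does the size of this same step on the cores of compound 1 and compound 2.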